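A few compounds are considered here, and "the series" means these few. Any claim that something is new, unique, unknown or untested is made for them only; others in the source may bear on it.

Working notes on the series. Among the compounds with values here, the shared core carries a propylene diamine chain ending in a furanylmethyl group, and the three compounds measured so far differ only in the substituent on the aromatic carbon of that core. Compound 1 `CC(C)Cc1ccc2c(NCCCNCc3ccco3)ccnc2c1` gives 16000 nM in an ADME assay on HepG2 cells (Homo sapiens) for cytotoxicity, read by luminescence, CellTiter-Glo and ATP content, with a stated time of 72 h; on this read-out higher numbers stand for an effect only at larger amounts of compound and lower numbers for an effect already at smaller amounts; compound 2 `c1ccc(Oc2ccc3c(NCCCNCc4ccco4)ccnc3c2)cc1` gives 15200 nM; compound 3 `CC(C)CCc1ccc2c(NCCCNCc3ccco3)ccnc2c1` gives 11200 nM. Compound 3 shows the lowest of the three numbers, yet the steps of a 1.4-fold lower number from compound 1 to compound 3 (0.15 log units; within the scatter) and a 1.4-fold lower number from compound 2 to compound 3 (0.13 log units; within the scatter) are both within the scatter, as is a 1.1-fold lower number from compound 1 to compound 2 (0.02 log units; within the scatter), so the three compounds are not separated in this assay.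

Compound 4 `Fc1ccc(Cc2ccc3c(NCCCNCc4ccco4)ccnc3c2)c(Cl)c1` is not yet measured. It differs from compound 3 by 2-chloro-4-fluorophenyl in place of isobutyl on a saturated chain carbon bound to an aromatic carbon. Within the data shown here, the steps that bear on this change are a 1.4-fold lower number from compound 1 to compound 3 (0.15 log units; within the scatter) and a 1.4-fold lower number from compound 2 to compound 3 (0.13 log units; within the scatter), which show that exchanging the group at this position, including the switch to a phenoxy group, left the number within the scatter. A step of a 1.2-fold lower number from compound 3 to compound 4 (0.07 log units; within the scatter) is therefore expected, with no direction beyond the scatter. Compound 4 is estimated at 9500 nM, in the range 3500 nM to 26000 nM.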

Compound 4, half-maximal effective concentration: 5730 nM
Compound 4: middle estimate off by 1.7-fold (0.22 log units), on the high side; the range from low to high includes it.
By their numbers in this assay, from the lowest: compounds 4, 3, 2 and 1 (each within the scatter of the next, the first and the last beyond it).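

In this assay the step of a 2.0-fold lower number from compound 3 to compound 4 (0.29 log units; within the scatter) stays within the scatter, so exchanging isobutyl for 2-chloro-4-fluorophenyl on a saturated chain carbon bound to an aromatic carbon does not separate that pair. Within the data shown here, the steps of a 2.7-fold lower number from compound 2 to compound 4 (0.42 log units; beyond the scatter) and a 2.8-fold lower number from compound 1 to compound 4 (0.45 log units; beyond the scatter) are the first beyond the scatter, though modest, so changes at this position can separate compounds, with compound 4 standing apart from compound 1 and compound 2 but not from compound 3. Nothing measured here gives a reason for these differences.

The compounds shown leave open how much of these steps belongs to the ring and how much to its chlorine and fluorine. On these data alone, it also remains open how the number would respond to an unsubstituted benzyl group, an amine or a carboxylic acid at this place.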